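Two oxazolone carbamates at a stability limit, and a third

A few compounds are considered here, and "the series" means these few. Any claim that something is new, unique, unknown or untested is made for them only; others in the source may bear on it.

Compound 1, `O=C(NCCCCc1ccccc1)n1cc(-c2ccccc2)oc1=O`, was tested in an ADME assay on a cell-free system (plasma, Mus musculus) for metabolic stability, read by LC-MS, tested at 2 uM; a higher number here means that the compound lasts longer, a lower number that the compound disappears faster. In this assay compound 1 gives < 0.0834 h, which is a limit of the assay rather than a number. Compound 2, `CCCCCNC(=O)n1cc(-c2ccccc2)oc1=O`, differs from it by methyl in place of phenyl on a saturated chain carbon, four bonds along the chain from an amide-type nitrogen. Compound 2 gives > 2 h, again a limit. The step of an at least 23-fold higher number from compound 1 to compound 2 (1.37 log units; beyond the scatter) therefore runs from one limit to the other, as the limit of < 0.0834 h in this assay, at which 1 of the 3 values shown sits, and the limit of > 2 h in this assay, at which 2 of the 3 values shown sit, show.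

Compound 3, `CN1CCC(c2cc(F)ccc2-c2cn(C(=O)NCCCCc3ccccc3)c(=O)o2)CC1`, carries a different core; how its core differs from that of compound 1 is not broken down here. Compound 3 gives > 2 h, also a limit of the assay.

Compound 4, `CCCCCNC(=O)n1cc(-c2ccc(F)cc2C2CCN(C)CC2)oc1=O`, has not yet been measured in this assay. It differs from compound 3 by methyl in place of phenyl on a saturated chain carbon, four bonds along the chain from an amide-type nitrogen, the same change that separates compound 2 from compound 1, made at the same place. Compound 4 is expected to show a step that the limit leaves unreadable from compound 3 to compound 4 from its parent. That expectation rests on the step of an at least 23-fold higher number from compound 1 to compound 2 (1.37 log units; beyond the scatter), which moved the half-life upward under the same change, while the starting point is already at the upper edge of what the assay reports. Compound 4 is accordingly estimated at 4 h, with a likely range from 2 h to 12 h, and a real chance that the assay again returns only a limit.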

Compound 4, half-life: 1.83 h
Beside the measured number, compound 4's estimate is 2.2-fold (0.34 log units) above it, and the stated range ends above it.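

In this assay, the replacement of phenyl by methyl on the chain did not carry its effect over from the core of compound 1 to the core of compound 3: the same change on two cores in this assay, an at least 23-fold higher number (1.37 log units; beyond the scatter) from compound 1 to compound 2 and an at least 1.0-fold lower number (0.03 log units; that floor lies within the scatter) from compound 3 to compound 4, at least 26-fold (1.41 log units) apart, beyond the scatter of two such steps

Compound 3 gives > 2 h, which is a limit of the assay. That leaves an at least 1.0-fold lower number from compound 3 to compound 4 (0.03 log units; that floor lies within the scatter) as a floor only, so the series shows that the large rise seen on the core of compound 1 did not recur on the core of compound 3, but it does not show how far the half-life truly moves on that second core, or even in which direction, and two cores give no rule for any other core.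

The compounds shown leave open how the half-life responds when the phenyl gives way to something other than methyl on either core, such as an amine, a carboxylic acid or a longer chain. They also leave open which part of the core of compound 3 sets it apart from the core of compound 1, as the two cores are compared here only as wholes.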